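Removing a Methyl From Compound 3

A few compounds are considered here, and "the series" means these few. Any claim that something is new, unique, unknown or untested is made for them only; others in the source may bear on it.

In a functional assay on MIA PaCa-2 cells (Homo sapiens) for antiproliferative activity, read by sulforhodamine B assay, with a stated time of 48 h (on this read-out higher numbers stand for weaker inhibition and lower numbers for stronger inhibition), compound 3 (`COc1cc(OC)c2sc(-c3ccc(N/C=C\C(=O)c4cc(OC)c(OC)c(OC)c4)c(C)c3)nc2c1`) gives 17000 nM. Compound 1 (`COc1cc(OC)c2sc(-c3ccc(N/C=C\C(=O)c4ccc(OC)c(O)c4)cc3)nc2c1`) gives 11600 nM, which is within the scatter of compound 3. Compound 2 (`COc1cc(OC)c2sc(-c3ccc(N/C=C\C(=O)c4ccc(OC)c([N+](=O)[O-])c4)cc3)nc2c1`) gives 2900 nM, a number clearly lower than that of compound 3.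

The next analogue, compound 4 (`COc1cc(OC)c2sc(-c3ccc(N/C=C\C(=O)c4cc(OC)c(OC)c(OC)c4)cc3)nc2c1`), has hydrogen in place of methyl on an aromatic carbon, ortho to a large group and meta to a large group: hydrogen in place of methyl on an aromatic carbon. Among the compounds with values here, no measured step covers this change. The only one available, a 4.0-fold lower number from compound 1 to compound 2 (0.60 log units; beyond the scatter), is nitro in place of hydroxy on an aromatic carbon, at another place in the molecule. It shows only that one small substitution can produce a modest shift in these compounds. Neither compound 1 nor compound 2 carries the methyl, but they also differ from compound 3 elsewhere, so they offer weak support for a lower number. A modest move downward is therefore expected, possibly no larger than the scatter.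

The expected change is a 2.1-fold lower number from compound 3 to compound 4 (0.33 log units; beyond the scatter). For compound 4 the estimated value is 8000 nM, with an expected range of 2500 nM to 20000 nM.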

Compound 4, half-maximal inhibitory concentration: 26800 nM
Compound 4: the middle estimate sits 3.4-fold (0.53 log units) below what was measured; measured number above the stated range.
By their numbers in this assay, from the lowest: compound 2; then compounds 1, 3 and 4 (each within the scatter of the next, the first and the last beyond it).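

In this assay, replacing the methyl with hydrogen on this aromatic carbon, ortho to a large group and meta to a large group, gives a step that stays within the scatter (a 1.6-fold higher number from compound 3 to compound 4 (0.20 log units; within the scatter)), so with the 3,4,5-trimethoxyphenyl group in place, these compounds do not separate methyl from hydrogen here. The methyl-free compound 4 also allows the group on the carbonyl carbon to be compared directly, and both steps lie beyond the scatter: a 9.2-fold higher number from compound 2 to compound 4 (0.97 log units; beyond the scatter) and a 2.3-fold higher number from compound 1 to compound 4 (0.36 log units; beyond the scatter). Nothing available explains these steps.

The compounds shown compare only methyl and hydrogen at this position, leaving open how an amine or a longer chain there would read. From the compounds shown here alone, it also remains open whether methyl and hydrogen would stay within the scatter alongside the 4-methoxy-3-nitrophenyl group.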